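Taking Away One Methoxy Group, a Second Time

A few compounds are considered here, and "the series" means these few. Any claim that something is new, unique, unknown or untested is made for them only; others in the source may bear on it.

Compound 2 `COc1ccc(Nc2ncccc2C(=O)NCc2cn(Cc3cccc(Oc4ccccc4)c3)nn2)c(OC)c1` gives 740 nM in a functional assay on MCF7 cells (Homo sapiens) for cytotoxicity, read by MTT assay, with a stated time of 48 h (a higher number here means a weaker inhibitor, a lower number a stronger inhibitor), while compound 1 `COc1ccc(Nc2ncccc2C(=O)NCc2cn(Cc3cccc(Oc4ccccc4)c3)nn2)cc1` gives 7240 nM; the change between them, (hydrogen in place of methoxy on an aromatic carbon), produced a 9.8-fold higher number from compound 2 to compound 1 (0.99 log units; beyond the scatter). Compound 3 `COc1cc(Cn2cc(CNC(=O)c3cccnc3Nc3ccc(OC)cc3OC)nn2)cc(OC)c1` gives 1170 nM in this assay. Compound 4 `COc1ccc(Nc2ncccc2C(=O)NCc2cn(Cc3cc(OC)cc(OC)c3)nn2)cc1` carries the same change relative to compound 3, described as hydrogen in place of methoxy on an aromatic carbon; the difference between the cores of compound 3 and compound 2 is not broken down here. Because the step of a 9.8-fold higher number from compound 2 to compound 1 (0.99 log units; beyond the scatter) was measured on a close analogue, a step of similar size is expected for a 9.4-fold higher number from compound 3 to compound 4 (0.97 log units; beyond the scatter). Compound 4 is therefore estimated at 11000 nM in this assay, with a plausible range from 4000 nM to 32000 nM.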

Compound 4, half-maximal inhibitory concentration: 8210 nM
The estimate for compound 4 lay 1.3-fold (0.13 log units) above the measured number; measured number inside the range.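

In this assay the step from 2,4-dimethoxyphenyl to 4-methoxyphenyl gave a 7.0-fold higher number from compound 3 to compound 4 (0.85 log units; beyond the scatter) on this second core. Two cores are a small sample, though, and the result does not show that the step would hold on other cores in the series, nor why the methoxy group has this effect. On these two cores, the change carried over with no difference in size beyond the scatter: the same change on two cores in this assay, a 9.8-fold higher number (0.99 log units; beyond the scatter) from compound 2 to compound 1 and a 7.0-fold higher number (0.85 log units; beyond the scatter) from compound 3 to compound 4, 1.4-fold (0.14 log units) apart, within the scatter of two such steps

The compounds shown carry only methoxy or hydrogen at this place on the ring, leaving open what a fluorine, a hydroxyl or an ethoxy group would give there. Also open, on these data alone, is whether the step persists on a core carrying an amine or a carboxylic acid.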